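The compounds below may be only part of what the source reports. "The series", "measured", "known", "first", "only" and "open" are said of these compounds alone.

In a functional assay (a higher number here means a weaker inhibitor, a lower number a stronger inhibitor), compound 1 (`CC(C)=CCOc1ccc2c(c1)OC(c1ccc(C)cc1)CC2=O`) gives 4440 nM, compound 2 (`CC(C)=CCOc1cc(O)c2c(c1)OC(c1cccc(F)c1)CC2=O`) gives 7240 nM and compound 3 (`CC(C)=CCOc1cc(O)c2c(c1)OC(c1ccc(Br)cc1)CC2=O`) gives 2770 nM. Compound 3 therefore lies within the scatter of compound 1 but clearly apart from compound 2. Among the measured compounds shown here, the only measured step between compounds differing in one place is a 2.6-fold lower number from compound 2 to compound 3 (0.42 log units; beyond the scatter), and it came with 4-bromophenyl in place of 3-fluorophenyl.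

Compound 4 (`CC(C)=CCOc1cc(O)c2c(c1)OC(c1ccc(C)cc1)CC2=O`) has not been measured yet. It has methyl in place of bromo on an aromatic carbon, para to a large group: methyl in place of bromo on an aromatic carbon. The measured step was modest and involved a different swap, so it offers only loose guidance. Compound 1 carries the same 4-methylphenyl group on a core that is not identical, and its value of 4440 nM is the closest available guide. Little change is therefore expected, with no step beyond the scatter in either direction. The expected step is a 1.3-fold higher number from compound 3 to compound 4 (0.10 log units; within the scatter). For compound 4 the estimated value is 3500 nM, with an expected range of 1500 nM to 8000 nM.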

Compound 4, half-maximal inhibitory concentration: 4360 nM
Beside the measured number, compound 4's estimate is 1.2-fold (0.10 log units) below it; low and high end bracket the measured number.
By their numbers in this assay, from the lowest: compounds 3, 4, 1 and 2 (each within the scatter of the next, the first and the last beyond it).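

In this assay, replacing bromo with methyl on the aromatic ring gives a 1.6-fold higher number from compound 3 to compound 4 (0.20 log units; within the scatter) and so leaves the two groups indistinguishable at this place. Compared with the 3-fluorophenyl compound, 4-methylphenyl gives a 1.7-fold lower number from compound 2 to compound 4 (0.22 log units; within the scatter) and so stays within the scatter, whereas 4-bromophenyl gave a 2.6-fold lower number from compound 2 to compound 3 (0.42 log units; beyond the scatter) and went beyond it. The new pair also tests a second place on the shared core, where hydroxy in place of hydrogen gives a 1.0-fold lower number from compound 1 to compound 4 (0.01 log units; within the scatter) and thus no visible gain or loss from that group.

No outside measurement offers an explanation for these results. From the compounds shown here alone, it remains open whether a group such as an amine, a carboxylic acid or a longer chain at the 4-position of this phenyl ring would shift the number beyond the scatter.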